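The source may report more compounds than this note shows. Statements on the series, on what has been measured and on what is new or still open speak of the compounds shown alone.

Compound 3 `CC(CSc1nnc(-c2ccncc2)s1)C(=O)NCc1ccccc1Cl` is one of a small set that shares a core and differs in the group carried on the amide-type nitrogen and in a methyl on the chain. In an ADME assay on BHK-21 cells (Mesocricetus auratus) for cytotoxicity, with a stated time of 3 days (on this read-out lower numbers stand for higher toxicity in this test and higher numbers for lower toxicity in this test), compound 3 reaches only the limit of the test, > 50000 nM. Compound 2 `O=C(CCSc1nnc(-c2ccncc2)s1)NCc1ccccc1Cl` likewise stops at a limit in this assay, > 50000 nM. Compound 1 `O=C(CCSc1nnc(-c2ccncc2)s1)Nc1ccc(Cl)cc1` gives a number in this assay, 8210 nM, and the step of an at least 6.0-fold higher number from compound 1 to compound 2 (0.78 log units; beyond the scatter) shows that exchanging the aryl group on the nitrogen moved the value well beyond the scatter, while a step that the two limits leave unreadable from compound 2 to compound 3 cannot be read. Compound 4 `CC(CSc1nnc(-c2ccncc2)s1)C(=O)Nc1ccc(Cl)cc1` differs from compound 3 by 4-chlorophenyl in place of 2-chlorobenzyl on an amide-type nitrogen, which is the reverse of the change from compound 1 to compound 2. For compound 4 a lower number in this assay is therefore expected, an estimated step of an at least 5.0-fold lower number from compound 3 to compound 4 (0.69 log units; beyond the scatter), since the step from compound 1 to compound 2 went the other way. Compound 4 is expected at about 10000 nM, between 3500 nM and 45000 nM.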

Compound 4, half-maximal cytotoxic concentration: > 50000 nM
Compound 4 ended at the assay's limit (the forecaster's own chance of this, stated with the estimate: 25%); at least 5.0-fold (0.69 log units) between middle value and limit.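

Compound 4 shows that 4-chlorophenyl on the amide-type nitrogen does not always go with a measurable value in this assay, as its result is a limit, > 50000 nM. Methyl in place of hydrogen on the saturated chain carbon bound to the carbonyl carbon gives an at least 6.0-fold higher number from compound 1 to compound 4 (0.78 log units; beyond the scatter), so a change on the chain can matter here as well as a change on the nitrogen. Steps between two limits cannot be read, so the effect of exchanging 4-chlorophenyl for 2-chlorobenzyl on the methyl-bearing chain stays hidden, and the comparison stops at one ceiling: the limit of > 50000 nM in this assay, at which 3 of the 4 values shown sit.

From the compounds shown here alone, how far above that limit compound 2, compound 3 and compound 4 truly lie remains open. Also open, going by these compounds, is whether an ethyl on the same chain carbon, or a carboxylic acid on the aromatic ring of the nitrogen group, would give a number.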